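The source may hold more compounds than are shown below. What is called first, only, known or untested is meant among the compounds shown, and "the series" means these compounds.

Series notes. The shared core carries a thiophen-3-yl group and two hydroxyphenyl groups. Compound 1 `Oc1cccc(-c2cc(-c3ccsc3)cc(-c3ccccc3O)n2)c1` is the member with a 2-hydroxyphenyl group. For compound 1 the value in a functional assay on T47D cells (Homo sapiens) for cytotoxicity, read by CCK-8 assay (on this read-out higher numbers stand for weaker inhibition and lower numbers for stronger inhibition), is a limit, > 50000 nM, namely (the limit of > 50000 nM in this assay, at which 1 of the 3 values shown sits). Compound 2 `Oc1cccc(-c2cc(-c3ccsc3)cc(-c3cccc(O)c3)n2)c1` carries a 3-hydroxyphenyl group in its place, and in this assay compound 2 gives 1510 nM. Compound 3 `Oc1ccc(-c2cc(-c3ccsc3)cc(-c3cccc(O)c3)n2)cc1` has a 4-hydroxyphenyl group there, and in this assay compound 3 gives 760 nM. The measured steps are an at least 33-fold lower number from compound 1 to compound 2 (1.51 log units; beyond the scatter) and an at least 65-fold lower number from compound 1 to compound 3 (1.81 log units; beyond the scatter), both large, whereas a 2.0-fold lower number from compound 2 to compound 3 (0.30 log units; within the scatter). Among the two numbers, compound 2 stands highest, with compound 3 nearest and within the scatter.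

Compound 4 `Oc1cccc(-c2cc(-c3ccco3)cc(-c3cccc(O)c3)n2)c1` differs from compound 2 in one place: furan-2-yl in place of thiophen-3-yl on an aromatic carbon. Within the data shown here, none of the measured steps touches this position; all three vary the hydroxyphenyl groups while the thiophen-3-yl group is kept. Among the measured compounds shown here, no measured step bears on an exchange of the five-membered hetero ring, so the expected step of a 1.0-fold lower number from compound 2 to compound 4 (0.00 log units; within the scatter) is none beyond the scatter. Compound 4 is therefore expected to give 1500 nM in this assay, within a range from 500 nM to 5000 nM.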

Compound 4, half-maximal inhibitory concentration: 3520 nM
Estimate against measurement, compound 4: 2.3-fold (0.37 log units) below, and the stated range covers the measured number.
By their numbers in this assay, from the lowest: compounds 3 and 2 (each within the scatter of the next); then compound 4. At a limit, above all of these: compound 1.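

Among these compounds, the position opposite the ring nitrogen responds to the five-membered ring it carries: with both 3-hydroxyphenyl groups kept, furan-2-yl in place of thiophen-3-yl gives a 2.3-fold higher number from compound 2 to compound 4 (0.37 log units; beyond the scatter) in this assay, the first step at this position, and it is far smaller than the large step seen among the hydroxyphenyl groups, an at least 33-fold lower number from compound 1 to compound 2 (1.51 log units; beyond the scatter). The two groups match in every count computed for them. They differ in oxygen for sulfur and in the point of attachment on the five-membered ring, and this single step cannot separate the two. No measured property in hand accounts for the step.

Open, as far as these compounds go, is whether thiophen-2-yl or furan-3-yl would assign the step to the hetero atom or to the point of attachment, and whether the same exchange carries over to the compound 3 background with its 4-hydroxyphenyl group. Also open, from the compounds shown here alone, is how this position tolerates a group of another kind, such as a plain phenyl ring, an amine or a longer alkyl chain.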